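The source may report more compounds than this note shows. Statements on the series, on what has been measured and on what is new or still open speak of the compounds shown alone.

Compound 1 `COc1cc(/C=C/C(=O)O)ccc1OC(=O)c1nc(C)c(C)nc1C`: 40.3%
Compound 2 `COc1ccc(/C=C/C(=O)O)cc1OC(=O)c1nc(C)c(C)nc1C`: 128%
Compound 3 `COc1cc(/C=C/C(=O)O)cc(OC)c1OC(=O)c1nc(C)c(C)nc1C`: 24%

In a functional assay on EA.hy 926 cells (Homo sapiens) for cytotoxicity, read by MTT assay, with stated times of 24 h and 12 h, tested at 25 uM (on this read-out higher numbers stand for a stronger effect at the one concentration tested and lower numbers for a weaker effect), compound 1 stands second highest of the three numbers. Its nearest neighbour is compound 3, reached by a number 16.3 percentage points lower from compound 1 to compound 3 (beyond the scatter), a step beyond the scatter. Compound 2 lies furthest away, giving 128%, far above compound 1.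

Compound 4 `Cc1nc(C)c(C(=O)Oc2ccc(/C=C/C(=O)O)cc2O)nc1C` differs from compound 1 in one place: hydrogen in place of methyl on an oxygen on an aromatic ring. Among the measured compounds shown here, no measured step concerns this kind of change; the only step recorded, a number 16.3 percentage points lower from compound 1 to compound 3 (beyond the scatter), adds a methoxy on an aromatic carbon, a different alteration. There is therefore no basis for expecting a step beyond the scatter in either direction, and compound 4 is estimated at 40%, between 15% and 70%, meaning an expected a number 0.3 percentage points lower from compound 1 to compound 4 (within the scatter).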

Compound 4, a percentage reported as activity, at one concentration (the size of the read-out at that concentration, not a potency): 271%
Compound 4: middle estimate off by 231 percentage points, on the low side, and the stated range ends below it.
By their numbers in this assay, from the lowest: compound 3; then compound 1; then compound 2; then compound 4.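

Removing one methyl from the oxygen on the aromatic ring, turning methoxy into hydroxy, gives a number 230.7 percentage points higher from compound 1 to compound 4 (beyond the scatter) in this assay. Among the compounds shown here, the only earlier step added a methoxy on an aromatic carbon and lowered the number, so this result shows that the read-out can also move sharply upward with a single small change at this oxygen. Nothing available here explains the rise. The compounds shown leave open what an ethyl group on this oxygen would give, or an amine in place of the hydroxy.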